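A Second Fluorine Added to a Methoxy-Bearing Ring

The source may hold more compounds than are shown below. What is called first, only, known or untested is meant among the compounds shown, and "the series" means these compounds.

Three compounds share one core and differ only on the ring that carries the methoxy group. Compound 1 is `COc1ccccc1C1CCN(c2ccn3c(CC4CC4)nnc3c2Cl)CC1`. In an ADME assay on a cell-free system (plasma, Homo sapiens) for protein binding (on this read-out lower numbers stand for a smaller free fraction and higher numbers for a larger free fraction), compound 1 gives < 0.01, which is a limit of the assay rather than a number. Compound 2 is `COc1cccc(F)c1C1CCN(c2ccn3c(CC4CC4)nnc3c2Cl)CC1`. In this assay compound 2 gives < 0.01, again a limit. Compound 3 is `COc1c(F)cccc1C1CCN(c2ccn3c(CC4CC4)nnc3c2Cl)CC1`. In this assay compound 3 gives < 0.01, also a limit. Because every value sits at the limit of < 0.01 in this assay, at which 3 of the 3 values shown sit, the steps among the three cannot be sized: a step that the two limits leave unreadable from compound 1 to compound 2, a step that the two limits leave unreadable from compound 1 to compound 3 and a step that the two limits leave unreadable from compound 2 to compound 3 all stay unreadable. Compound 3 thus stands at the limit with the other two, with no number behind it.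

Compound 4 is `COc1c(C2CCN(c3ccn4c(CC5CC5)nnc4c3Cl)CC2)ccc(F)c1F`. It differs from compound 3 by fluoro in place of hydrogen on an aromatic carbon. Going by the values given here, the steps that bear on this change are the two other fluoro-for-hydrogen exchanges, and both are unreadable, as is the exchange between the two fluorinated compounds. What the measurements do show is that three compounds already sit at the limit, so compound 4 is expected to show a step that the limit leaves unreadable from compound 3 to compound 4 that again cannot be read. Compound 4 is estimated at 0.005, within 0.002 to 0.012, most probably reported once more as a limit in this assay.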

Compound 4, unbound fraction: < 0.01
Compound 4 ended at the assay's limit; the forecaster's own chance of this, stated with the estimate: 85%; the middle value is on the limit's open side.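

In this assay compound 4 gives < 0.01, which is again a limit and not a number. Going by these compounds alone, no step from compound 1, compound 2 or compound 3 to compound 4 can be read: the limit of < 0.01 in this assay, at which 4 of the 4 values shown sit. The compounds shown leave open how large the free fraction of each one really is, and whether any fluoro exchange alters it.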